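The source may report more compounds than this note shows. Statements on the series, on what has been measured and on what is new or still open speak of the compounds shown alone.

Three ureas share one core and are measured in a functional assay on KETR3 cells (Homo sapiens) for inhibition, read by MTT assay, with a stated time of 120 h; a lower number here means a stronger inhibitor, a higher number a weaker inhibitor. Compound 1 `CNC(=O)/C(C)=C/c1ccc(NC(=O)Nc2ccc(Cl)c(C(F)(F)F)c2)cc1` gives > 50000 nM, which is a limit of the assay and not a number. Compound 3 `CNC(=O)/C=C(\C)c1ccc(NC(=O)Nc2ccc(Cl)c(C(F)(F)F)c2)cc1` gives > 50000 nM, again a limit. Compound 2 `C/C(=C\C(=O)N1CC(C)OC(C)C1)c1ccc(NC(=O)Nc2ccc(Cl)c(C(F)(F)F)c2)cc1` gives > 50000 nM, also a limit. The cores of compound 1 and compound 3 differ as 2-(methylcarbamoyl)prop-1-en-1-yl in place of 1-methyl-2-(methylcarbamoyl)ethenyl on an aromatic carbon, and the step that the two limits leave unreadable from compound 1 to compound 3 cannot be read from two limits. From compound 3 to compound 2 the change is 2,6-dimethylmorpholin-4-yl in place of methylamino on a carbonyl carbon, with the step that the two limits leave unreadable from compound 3 to compound 2 likewise unreadable. Compound 4 `C/C(=C\c1ccc(NC(=O)Nc2ccc(Cl)c(C(F)(F)F)c2)cc1)C(=O)N1CC(C)OC(C)C1` carries the same change on the core of compound 1, described as 2,6-dimethylmorpholin-4-yl in place of methylamino on a carbonyl carbon. Since all three values sit at the limit of > 50000 nM in this assay, at which 3 of the 3 values shown sit, the step of a number no higher from compound 1 to compound 4 (the limit leaves the size open) is expected to be flat, resting on the unreadable a step that the two limits leave unreadable from compound 3 to compound 2. Compound 4 is estimated at 50000 nM in this assay, most likely reported only as a limit.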

Compound 4, half-maximal inhibitory concentration: > 50000 nM
Compound 4: only a limit was reported; the forecaster's own chance of this, stated with the estimate: 85%; the middle value lies on the limit itself.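

No new step can be read between compound 1 and compound 4 in this assay because both values are limits and not numbers: the limit of > 50000 nM in this assay, at which 4 of the 4 values shown sit.

The compounds shown leave open how methylamino and 2,6-dimethylmorpholin-4-yl compare on the carbonyl carbon, and at what concentration any of the four compounds would give a number in this assay at all.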